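The compounds below may be only part of what the source reports. "The series", "measured", "known", "first", "only" and "open" are said of these compounds alone.

Measured so far:
compound 1 `ClCc1cccc(Cn2cnc3nc(Cl)nc(Cl)c32)c1` — 4670 nM
compound 2 `ClCc1ccccc1Cn1cnc2nc(Cl)nc(Cl)c21` — 6760 nM

Both values come from a functional assay on UACC-62 cells (Homo sapiens) for cytotoxicity, read by sulforhodamine B assay, with a stated time of 48 h; a lower number here means that less compound is tolerated, a higher number that more compound is tolerated. In this assay compound 2 gives the highest of the two numbers, but its nearest neighbour, compound 1, differs from it only within the scatter, so the two compounds are not separated by these data. Among the measured compounds shown here, no pair of the measured compounds differs in a single place, so no measured step is available as a guide for the next change.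

Compound 3 `ClCc1ccccc1Cn1cnc2ncnc(Cl)c21` is the next compound to be run in this assay. It is derived from compound 2 by hydrogen in place of chloro on an aromatic carbon. The change removes one of the two chloro groups of the shared core while everything else in compound 2 is kept.

With no measured step of this kind in hand, the step is expected to be modest, in the direction of a higher number, meaning more compound tolerated, of about the size given by a 1.8-fold higher number from compound 2 to compound 3 (0.25 log units; within the scatter). Compound 3 is expected to give 12000 nM in this assay, with a range of 4000 nM to 35000 nM. A result close to the value of compound 2 remains possible, as does a limit if the number runs high.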

Compound 3, concentration lethal to 50% of the cells: 19100 nM
Beside the measured number, compound 3's estimate is 1.6-fold (0.20 log units) below it; the range from low to high includes it.
By their numbers in this assay, from the lowest: compounds 1 and 2 (each within the scatter of the next); then compound 3.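

In this assay, among the compounds shown here, replacing chloro with hydrogen on the aromatic carbon between two ring nitrogen atoms gives a 2.8-fold higher number from compound 2 to compound 3 (0.45 log units; beyond the scatter), the first step that lies beyond the scatter, whereas compound 1 and compound 2 could not be separated by their values. This position on the shared core therefore matters to the cytotoxicity read-out, and in this pair the chloro group goes with less compound being tolerated, although that reading rests on a single pair with the chloromethyl group and the remaining chloro group unchanged. No supporting measurement is available to explain the size or direction of this step.

The compounds shown leave open whether the same change would give a comparable step with the chloromethyl group placed as in compound 1, and what removing or replacing the remaining chloro group would do. They also do not show whether an amine or a methoxy group on the carbon between the two ring nitrogen atoms would give a number closer to that of compound 2 or that of compound 3.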